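Compound 3: 2-chlorophenyl in place of 3-methylphenyl

This account rests on a few compounds, and the source may have more. Where it says the series, first, only, none or still open, it means among the compounds named here.

Measured in a functional assay on SGC-7901 cells (Homo sapiens) for antiproliferative activity, read by MTT assay, with a stated time of 24 h; on this read-out lower numbers stand for stronger inhibition and higher numbers for weaker inhibition:
Compound 1 `Cc1ccccc1NNC(=O)c1ccc(NS(=O)(=O)c2cnc(O)nc2O)cc1`: > 20000 nM (a limit)
Compound 2 `Cc1cccc(NNC(=O)c2ccc(NS(=O)(=O)c3cnc(O)nc3O)cc2)c1`: > 20000 nM (a limit)

Compound 2 has no actual number in this assay. Compound 2 stands at > 20000 nM, which is a limit of the assay. The two measured compounds share one position: the limit of > 20000 nM in this assay, at which 2 of the 2 values shown sit. Going by the values given here, the only measured step runs a step that the two limits leave unreadable from compound 1 to compound 2 and swaps 2-methylphenyl for 3-methylphenyl on an amine nitrogen.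

Compound 3 `O=C(NNc1ccccc1Cl)c1ccc(NS(=O)(=O)c2cnc(O)nc2O)cc1` has not yet been measured. It carries 2-chlorophenyl in place of 3-methylphenyl on an amine nitrogen, and the counted difference reads (2-chlorophenyl in place of 3-methylphenyl on an amine nitrogen). Among the compounds with values here, the one measured step bears on this change, but it offers no size to carry over. No direction can be read from it either. The expectation therefore rests on compound 2 and its limit of > 20000 nM. Compound 3 is expected to remain weak in this assay, and a further limit is the likeliest report. The expected step is a step that the limit leaves unreadable from compound 2 to compound 3, with no real change anticipated. For compound 3 the estimate is 25000 nM, with an expected range from 9000 nM to 60000 nM.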

Compound 3, half-maximal inhibitory concentration: 3630 nM
Compound 3: middle estimate off by 6.9-fold (0.84 log units), on the high side; the measured number lies below the stated range.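

In this assay, 2-chlorophenyl in place of 3-methylphenyl on an amine nitrogen gives an at least 5.5-fold lower number from compound 2 to compound 3 (0.74 log units; beyond the scatter), which shows that a change at this position alone can bring a readable number with the rest of the structure untouched. Chloro in place of methyl on an aromatic carbon gives an at least 5.5-fold lower number from compound 1 to compound 3 (0.74 log units; beyond the scatter), so the swap of that one group is enough, something the step between the two methylphenyl compounds could not show, as that step cannot be read. Both readable steps give only a minimum size, since compound 1 and compound 2 rest at one shared limit of the assay: the limit of > 20000 nM in this assay, at which 2 of the 3 values shown sit.

The compounds shown leave open whether chloro is special on this aromatic carbon or whether a bromo, fluoro or methoxy group there would give a similar number in this assay. As far as these compounds go, how far the true values of compound 1 and compound 2 lie from that of compound 3 also stays open, so the full size of the change remains unknown.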